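Dithiocarbamate chromone series: amine ring swap at the thiocarbonyl

The source may report more compounds than this note shows. Statements on the series, on what has been measured and on what is new or still open speak of the compounds shown alone.

Measured so far:
compound 1 `COc1ccc2occ(CSC(=S)N3CCOCC3)c(=O)c2c1` — > 40000 nM in a functional assay on LM7 cells (Homo sapiens) for antiproliferative activity, read by MTT assay, with a stated time of 72 h; on this read-out lower numbers stand for stronger inhibition and higher numbers for weaker inhibition
compound 2 `O=c1c(CSC(=S)N2CCOCC2)coc2ccccc12` — 12000 nM

Compound 1 gives only a limit in this assay, with no number behind it (the limit of > 40000 nM in this assay, at which 1 of the 2 values shown sits). Going by the values given here, compound 2 gives 12000 nM, and the step of an at least 3.3-fold lower number from compound 1 to compound 2 (0.52 log units; beyond the scatter) is the only measured change; it concerns a substituent on the aromatic ring, not the amine part.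

The next compound is compound 3 `COc1ccc2occ(CSC(=S)N3CCCCC3)c(=O)c2c1`. Its change from compound 1 is piperidin-1-yl in place of morpholin-4-yl on a thiocarbonyl carbon. Among the compounds with values here, no measured step touches this position, so nothing in the data points to a shift in either direction beyond the scatter, and the starting point is itself a limit. Compound 3 is therefore expected to remain weak, with a fair chance that this assay again reports only a limit. The expected step of a number no higher from compound 1 to compound 3 (the limit leaves the size open) is a guess around no change. The estimate for compound 3 is 40000 nM, between 10000 nM and 150000 nM.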

Compound 3, half-maximal inhibitory concentration: 4700 nM
The estimate for compound 3 lay 8.5-fold (0.93 log units) above the measured number; measured number below the stated range.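

In this assay, the amine ring on the thiocarbonyl carbon proves to be a position that moves the read-out, with an at least 8.5-fold lower number from compound 1 to compound 3 (0.92 log units; beyond the scatter) for piperidin-1-yl in place of morpholin-4-yl. Going by these compounds alone, the only earlier step concerned a substituent on the aromatic ring, so this is the first sign that the amine part alone can matter, here on the methoxy-bearing core of compound 1. Compound 1 gives only a limit, so the step sets a minimum and its true size stays open: the limit of > 40000 nM in this assay, at which 1 of the 3 values shown sits.

From the compounds shown here alone, whether the same ring swap carries over to the core of compound 2, which has hydrogen in place of methoxy, remains open. Also open, going by these compounds, is how other amines on the thiocarbonyl carbon would compare, such as 4-methylpiperazin-1-yl or an open-chain diethylamino group.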